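Fluoro to trifluoromethyl on the pyrazole aryl: two cores

The source may hold more compounds than are shown below. What is called first, only, known or untested is meant among the compounds shown, and "the series" means these compounds.

Compound 1 `Cn1ncc2c(NC(=O)NCc3cc(C(F)(F)F)nn3-c3ccc(F)cc3)cccc21` and compound 2 `Cn1ncc2c(NC(=O)NCc3cc(C(F)(F)F)nn3-c3ccc(C(F)(F)F)cc3)cccc21` share one core; compound 3 `CC(C)(C)c1cc(CNC(=O)Nc2cccc3[nH]ncc23)n(-c2ccc(F)cc2)n1` and compound 4 `CC(C)(C)c1cc(CNC(=O)Nc2cccc3[nH]ncc23)n(-c2ccc(C(F)(F)F)cc2)n1` share another. The difference between the two cores is not broken down here. In an assay on CHO-K1 cells for antagonist activity at transient receptor potential cation channel subfamily V member 1 (Homo sapiens), read by FLIPR and calcium flux, with a stated time of 6 min (on this read-out higher numbers stand for weaker inhibition and lower numbers for stronger inhibition), compound 1 gives 8.4 nM and compound 2 gives 3.9 nM; the change between them is trifluoromethyl in place of fluoro on an aromatic carbon, and it gave a 2.2-fold lower number from compound 1 to compound 2 (0.33 log units; beyond the scatter). In this assay compound 3 gives 2.2 nM, which against compound 2 is within the scatter and against compound 1 beyond it. Compound 4 carries the same change on the other core, (trifluoromethyl in place of fluoro on an aromatic carbon). Resting on the one step seen on compound 1 to compound 2, compound 4 is expected to show a 2.0-fold lower number from compound 3 to compound 4 (0.30 log units; within the scatter) relative to compound 3. The estimate for compound 4 in this assay is 1.1 nM, with a range from 0.5 nM to 2.6 nM.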

Compound 4, inhibition constant: 19.6 nM
Estimate against measurement, compound 4: 18-fold (1.25 log units) below; the measured number lies above the stated range.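

In this assay, trifluoromethyl in place of fluoro gave an 8.9-fold higher number from compound 3 to compound 4 (0.95 log units; beyond the scatter), so neither the size nor the direction of the step carried over from the core of compound 1 to the core of compound 3: the same change on two cores in this assay, a 2.2-fold lower number (0.33 log units; beyond the scatter) from compound 1 to compound 2 and an 8.9-fold higher number (0.95 log units; beyond the scatter) from compound 3 to compound 4, 19-fold (1.28 log units) apart, beyond the scatter of two such steps

For these two pairs, the outcome of the change depends on the core, and a step read on one core gives no sound estimate for the other. The two cores differ in more than one place, so these pairs do not show which difference goes with the reversal, and they give no cause for it.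

Open, on these data alone, is how the step behaves on a core that differs from either of these in one place only. Also open, as far as these compounds go, is whether a chloro or a nitrile on the same aromatic carbon would follow fluoro or trifluoromethyl on each core.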